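This account rests on a few compounds, and the source may have more. Where it says the series, first, only, none or still open, it means among the compounds named here.

Working notes on the series. In a functional assay for antagonist activity at transient receptor potential cation channel subfamily V member 1 (Rattus norvegicus) (a lower number here means a stronger inhibitor, a higher number a weaker inhibitor), compound 1 `Cc1cccnc1-c1ccc(C(=O)Nc2ccc(C(F)(F)F)cc2)cc1` gives 81 nM. In this assay compound 2 `CCS(=O)(=O)Nc1cccnc1-c1ccc(C(=O)Nc2ccc(C(C)(C)C)cc2)cc1` gives 4 nM, the lowest of the two numbers in hand, and the gap to its nearest neighbour, compound 1, is beyond the usual scatter of repeated measurement. Compound 3 `CC(C)(C)c1ccc(NC(=O)c2ccc(-c3ncccc3-c3nn[nH]n3)cc2)cc1` has not yet been measured in this assay. It differs from compound 2 in one place: 2H-tetrazol-5-yl in place of (ethylsulfonyl)amino on an aromatic carbon. Within the data shown here, no measured pair shows this change, so the size of the step is not anchored by any measured pair, and the two measured compounds differ from each other in more than one place, so their values alone do not isolate this exchange. The expectation for compound 3 is a moderate rise in the number, a weaker inhibitor than compound 2, but with wide uncertainty that still admits a value within the scatter of compound 2. The step expected here, a 3.8-fold higher number from compound 2 to compound 3 (0.57 log units; beyond the scatter), is read as beyond the scatter but not large. The estimate for compound 3 in this assay is 15 nM, with a range from 3 nM to 80 nM.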

Compound 3, half-maximal inhibitory concentration: > 4000 nM
Compound 3 gave a limit, no number (the forecaster's own chance of this, stated with the estimate: 5%); middle value at least 260-fold (2.42 log units) from the limit.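

In this assay, 2H-tetrazol-5-yl in place of (ethylsulfonyl)amino, on an aromatic carbon ortho to a large group and two atoms from the ring nitrogen, brings an at least 1000-fold higher number from compound 2 to compound 3 (3.00 log units; beyond the scatter), a large step and the only one in the series that isolates a single change at this position. For compound 3 the reading is a limit of the assay and not a number: the limit of > 4000 nM in this assay, at which 1 of the 3 values shown sits. The two groups match in carrying a hydrogen-bond donor, hydrogen-bond acceptors and no net charge and differ little in heavy-atom count, so these shared counts alone do not preserve the low number of compound 2 at this position.

Compound 1 differs from compound 2 in more than one place, so its methyl group gives no separate reading of this position, and the part played here by the sulfonyl unit or the ethyl chain of the (ethylsulfonyl)amino group remains unresolved. As far as these compounds go, how a carboxylic acid, a primary amine or a shorter methylsulfonylamino group would read at this position remains open in these compounds.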